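Working notes: open chain against ring on the shared core

The source may report more compounds than this note shows. Statements on the series, on what has been measured and on what is new or still open speak of the compounds shown alone.

Measured so far in an assay on CHO cells for antagonist activity at transient receptor potential cation channel subfamily V member 1 (Homo sapiens), read by FLIPR and calcium flux; a lower number here means a stronger inhibitor, a higher number a weaker inhibitor:
- compound 1, `CC(C(=O)NCc1ccc(C(F)(F)F)nc1CCC(C)(C)C)c1ccc(NS(C)(=O)=O)c(F)c1`: 0.6 nM
- compound 2, `C[C@H](C(=O)NCc1ccc(C(F)(F)F)nc1C1CCC(C)(C)CC1)c1ccc(NS(C)(=O)=O)c(F)c1`: 0.3 nM
- compound 3, `C[C@H](C(=O)NCc1ccc(C(F)(F)F)nc1C1CC2CCC1C2)c1ccc(NS(C)(=O)=O)c(F)c1`: 0.8 nM

All three sit close together. Compound 1 has the second highest of the three numbers; its nearest neighbour is compound 3, within the scatter, and compound 2 lies furthest from it, also within the scatter. Among the measured compounds shown here, the one single-point step among the measured compounds is a 2.7-fold higher number from compound 2 to compound 3 (0.43 log units; beyond the scatter), a modest rise that exchanges one ring for another on the aromatic carbon.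

Compound 4, `CC(C(=O)NCc1ccc(C(F)(F)F)nc1C1=CCC(C(C)(C)C)CC1)c1ccc(NS(C)(=O)=O)c(F)c1`, is not yet measured. It differs from compound 1 by 4-(tert-butyl)cyclohex-1-en-1-yl in place of 3,3-dimethylbutyl on an aromatic carbon. For the measured compounds named here, no measured step exchanges an open chain for a ring, so none bears directly on this change; compound 1 and compound 2, which differ in that way among other things, give values within the scatter of each other, and the only measured ring-to-ring step was modest. The expectation is therefore no step beyond the scatter in this assay for compound 4, with a 1.2-fold lower number from compound 1 to compound 4 (0.08 log units; within the scatter) as the estimated change. Compound 4 is expected to give about 0.5 nM in this assay, with a likely range from 0.15 nM to 1.6 nM.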

Compound 4, inhibition constant: 0.2 nM
For compound 4 the middle estimate is 2.5-fold (0.40 log units) above the measured one; low and high end bracket the measured number.
By their numbers in this assay, from the lowest: compounds 4, 2, 1 and 3 (each within the scatter of the next, the first and the last beyond it).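

In this assay, among the compounds shown here, a 3.0-fold lower number from compound 1 to compound 4 (0.48 log units; beyond the scatter) gives the first measured exchange of an open chain for a ring at this position, on the aromatic carbon next to the ring nitrogen, and the step lies beyond the scatter. For the compounds shown here, it shows that this position accepts the larger 4-(tert-butyl)cyclohex-1-en-1-yl group in place of 3,3-dimethylbutyl with a lower number, although the size of the step is modest and the single pair supports no wider pattern. The step changes the heavy-atom count, the ring and the double bond together, so it cannot be assigned to any one of them, and no measurement here bears on the reason for it.

The compounds shown leave open what the double bond contributes, a question that a saturated 4-(tert-butyl)cyclohexyl group at the same place on the shared core would address directly. They also leave open whether this position accepts anything other than carbon-only groups, such as an amine or an ether, or a longer chain in place of 3,3-dimethylbutyl.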